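The compounds below may be only part of what the source reports. "The series", "measured", "known", "first", "only" and "open" are said of these compounds alone.

Measured so far:
Compound 1 `CCCC(=O)C1=C(C)NC(=O)NC1c1ccco1` — 1%
Compound 2 `CC1=C(C(=O)CC(C)C)C(c2ccco2)NC(=O)N1` — 16%
Compound 3 `CC1=C(C(=O)OC2CCCCC2)C(c2ccco2)NC(=O)N1` — 1%

Within the data shown here, in an assay on membranes from CHO cells for displacement of a labelled ligand from adenosine receptor A1 (Homo sapiens), read by scintillation counting, with a stated time of 60 min, tested at 1 uM (on this read-out lower numbers stand for less inhibition and higher numbers for more inhibition at the one concentration tested (going by the name of the read-out)), compound 3 gives 1%, which is level with compound 1 and together the lowest of the three numbers; the only compound that stands clearly apart is compound 2 with 16%. Compound 4 `CC1=C(C(=O)OCC2CC2)C(c2ccco2)NC(=O)N1` has not yet been measured and differs from compound 3 in a single place: cyclopropylmethyl in place of cyclohexyl on an oxygen next to a carbonyl group.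

Two of the measured steps bear on this change, since both alter the group attached to the carbonyl carbon of the shared core. The step of no change at the digits printed from compound 1 to compound 3 (within the scatter) shows that exchanging propyl for cyclohexyloxy leaves the read-out where it was, while a number 15 percentage points lower from compound 2 to compound 3 (beyond the scatter) shows a modest drop when cyclohexyloxy replaces isobutyl. Neither of these steps involves cyclopropylmethyl, so there is no direct precedent for the change itself, and the only movement seen among these compounds comes from a chain carrying an extra methyl rather than from an ester.

Compound 4 is therefore expected to stay near compound 3, with a step of a number 4 percentage points higher from compound 3 to compound 4 (within the scatter) that does not go beyond the scatter. The estimate for compound 4 is 5%, with a range from 0% to 20%.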

Compound 4, a percentage reported as inhibition, at one concentration (the size of the read-out at that concentration, not a potency): 29%
Compound 4: middle estimate off by 24 percentage points, on the low side; the measured number lies above the stated range.
By their numbers in this assay, from the lowest: compounds 1 and 3 (each within the scatter of the next); then compound 2; then compound 4.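

In this assay the exchange of cyclohexyl for cyclopropylmethyl on an oxygen next to a carbonyl group gives a number 28 percentage points higher from compound 3 to compound 4 (beyond the scatter) and shows that the read-out responds to the group on this oxygen, which compound 3 alone could not show. The earlier compounds shown here left the only clear rise with a carbon chain on the carbonyl carbon, but cyclopropylmethoxy on that carbon now goes further, with a number 13 percentage points higher from compound 2 to compound 4 (beyond the scatter) and a number 28 percentage points higher from compound 1 to compound 4 (beyond the scatter) in the same read-out, so an ester here is not tied to a low number, although compound 3 stays low. No measurement among the data presented accounts for this rise.

With only two esters, the compounds shown leave open whether the rise follows the three-membered ring, the smaller count of heavy atoms or the carbon linking the ring to the oxygen, as these differences all arrive together in compound 4. A cyclohexylmethyl group, a cyclopropyl group directly on the oxygen or a straight butyl chain at this place would pull these apart, and all the numbers here come from a single concentration on a single receptor.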